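Aryl Replaces Amide on the Ring Nitrogen of Compound 3

The source may hold more compounds than are shown below. What is called first, only, known or untested is meant among the compounds shown, and "the series" means these compounds.

Compound 3 `CCC(=O)N1CCN(c2cc(NCCN)c3ccccc3n2)CC1` is one of three compounds that share a core and differ only in the group on an amine nitrogen in a ring. In an ADME assay on HEp-2 cells (Homo sapiens) for cytotoxicity, read by CCK-8 assay, with a stated time of 6 days (on this read-out higher numbers stand for lower toxicity in this test and lower numbers for higher toxicity in this test), compound 3 sits at the limit of the test, giving > 100000 nM. Compound 2 `NCCNc1cc(N2CCN(C(=O)CCc3ccccc3)CC2)nc2ccccc12` also sits at that limit, with > 100000 nM. For the measured compounds named here, compound 1 `NCCNc1cc(N2CCN(S(=O)(=O)c3ccccc3)CC2)nc2ccccc12` is the only member with a number, giving 20500 nM. The steps of an at least 4.8-fold higher number from compound 1 to compound 3 (0.68 log units; beyond the scatter) and an at least 4.8-fold higher number from compound 1 to compound 2 (0.68 log units; beyond the scatter) both run from that number to the limit of > 100000 nM in this assay, at which 2 of the 3 values shown sit, whereas a step that the two limits leave unreadable from compound 2 to compound 3 cannot be sized. Compound 4 `NCCNc1cc(N2CCN(c3ccc(Cl)cc3)CC2)nc2ccccc12` differs from compound 3 in that (4-chlorophenyl in place of propanoyl on an amine nitrogen in a ring). Going by the values given here, no measured step swaps an acyl group for an aryl group on that nitrogen; the nearest guide is compound 1, whose phenylsulfonyl group also carries an aromatic ring and whose value is a number below the limit. A move back toward a readable number is therefore expected for compound 4, an at least 2.5-fold lower number from compound 3 to compound 4 (0.39 log units; beyond the scatter), though with wide uncertainty. Compound 4 is estimated at 40000 nM, between 10000 nM and 100000 nM.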

Compound 4, half-maximal cytotoxic concentration: 6600 nM
Beside the measured number, compound 4's estimate is 6.1-fold (0.78 log units) above it; the measured number lies below the stated range.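

Placing 4-chlorophenyl on this ring nitrogen in place of an acyl group gives an at least 15-fold lower number from compound 3 to compound 4 (1.18 log units; beyond the scatter) and an at least 15-fold lower number from compound 2 to compound 4 (1.18 log units; beyond the scatter) in this assay. Against the phenylsulfonyl group it gives a 3.1-fold lower number from compound 1 to compound 4 (0.49 log units; beyond the scatter), so compound 4 has the lowest number of the four and the highest toxicity in this test, and a number below the limit at this position no longer belongs to the sulfonyl compound alone. The two larger steps start from a limit rather than a number, so their true sizes stay unknown: the limit of > 100000 nM in this assay, at which 2 of the 4 values shown sit.

The compounds shown leave open how much of the change belongs to the chlorine and how much to the aromatic ring, which a plain phenyl group on the same nitrogen would separate. From the compounds shown here alone, whether a benzyl group, with one carbon set before the ring, keeps the lower number also remains open.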